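The source may report more compounds than this note shows. Statements on the series, on what has been measured and on what is new or still open speak of the compounds shown alone.

Measured so far in an assay on cells with melanin-concentrating hormone receptor 1 (Homo sapiens) as the target, read by radioligand binding; on this read-out higher numbers stand for weaker inhibition and lower numbers for stronger inhibition:
compound 1 `Nc1ccc2cccc(OC3CCCCC3)c2n1` gives 361 nM
compound 2 `CCC(C)COc1cccc2ccc(N)nc12` gives 36 nM
compound 3 `Nc1ccc2cccc(OCCC3CCCCC3)c2n1` gives 808 nM

Compound 3 stands highest of the three numbers in this assay; compound 1 lies nearest to it and compound 2 furthest, both below it and both beyond the usual scatter.

Compound 4 `CC#CCCOc1cccc2ccc(N)nc12` is not yet measured. Going from compound 3 to compound 4: prop-1-yn-1-yl in place of cyclohexyl on a saturated chain carbon, two bonds along the chain from an oxygen on an aromatic ring. For the measured compounds named here, the only measured step that bears on this is the one from compound 1 to compound 2, where an acyclic chain replaced a cyclohexyl on the same oxygen: a 10-fold lower number from compound 1 to compound 2 (1.00 log units; beyond the scatter). That step removed a cyclohexyl ring and gave a clearly lower number; the present change also removes a cyclohexyl ring and leaves a chain without a ring on the oxygen. Going by the values given here, no measured step tests the triple bond itself, so the size carried over is uncertain. A lower number beyond the scatter is expected for compound 4, with the step of a 6.7-fold lower number from compound 3 to compound 4 (0.83 log units; beyond the scatter). The estimate for compound 4 in this assay is 120 nM, within the range 35 nM to 400 nM.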

Compound 4, half-maximal inhibitory concentration: > 2000 nM
Compound 4: no number, only a limit (the forecaster's own chance of this, stated with the estimate: 2%); middle value at least 16-fold (1.22 log units) away from the limit.
By their numbers in this assay, from the lowest: compound 2; then compound 1; then compound 3. At a limit, above all of these: compound 4.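

In this assay compound 4 is recorded only as a limit and not as a number: the limit of > 2000 nM in this assay, at which 1 of the 4 values shown sits. An acyclic chain on the oxygen therefore does not by itself give a lower number: pent-3-yn-1-yl in place of cyclohexyl gives an at least 5.5-fold higher number from compound 1 to compound 4 (0.74 log units; beyond the scatter), against the opposite direction with 2-methylbutyl in a 10-fold lower number from compound 1 to compound 2 (1.00 log units; beyond the scatter). The identity of the chain decides the outcome in this series, since but-2-yn-1-yl in place of sec-butyl gives an at least 55-fold higher number from compound 2 to compound 4 (1.74 log units; beyond the scatter), and prop-1-yn-1-yl in place of the cyclohexyl at the chain end gives an at least 2.4-fold higher number from compound 3 to compound 4 (0.39 log units; beyond the scatter).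

The compounds shown do not separate the triple bond from the loss of the branch in the chain. As far as these compounds go, a saturated pentyl chain on the same oxygen would bear on that, and the full size of these steps remains unknown.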